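Shortening the nitrooxy ester chain from compound 3

The source may report more compounds than this note shows. Statements on the series, on what has been measured and on what is new or still open speak of the compounds shown alone.

Measured so far in a functional assay on M14 cells (Homo sapiens) for cytotoxicity, read by resazurin assay, with a stated time of 72 h; a lower number here means a stronger inhibitor, a higher number a weaker inhibitor
compound 1 `COc1cc(/C=C/C(=O)OCCCCCCO[N+](=O)[O-])ccc1O` gives > 50000 nM (a limit)
compound 2 `COc1cc(/C=C/C(=O)OCCCO[N+](=O)[O-])ccc1OCCCO[N+](=O)[O-]` gives > 50000 nM (a limit)
compound 3 `COc1cc(/C=C/C(=O)OCCCCCO[N+](=O)[O-])ccc1O` gives 24500 nM (a number)

Among the compounds with values here, compound 3 carries the only true number (24500 nM). The other two compounds sit at the limit of > 50000 nM in this assay, at which 2 of the 3 values shown sit, and give no number to work from. The next compound is compound 4 `COc1cc(/C=C/C(=O)OCCCO[N+](=O)[O-])ccc1O` and the structural change is nitrooxy in place of 2-(nitrooxy)ethyl on a saturated chain carbon, three bonds along the chain from an oxygen next to a carbonyl group here. Within the data shown here, the one measured step on this chain is an at least 2.0-fold lower number from compound 1 to compound 3 (0.30 log units; that floor lies within the scatter) and, being only a floor, it sets no trend. The ester chain of compound 4 also occurs in compound 2, which is held at a limit (> 50000 nM). That compound differs elsewhere, so it is only a weak pointer toward a higher number. In this assay, among the measured compounds shown here, no step clearly beyond the scatter is therefore expected, with any drift going upward, toward the limit. The expected step is a 1.4-fold higher number from compound 3 to compound 4 (0.15 log units; within the scatter) in this estimate. Compound 4 is estimated at 35000 nM with an expected range from 15000 nM to 70000 nM and a real chance of reading out only as a limit.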

Compound 4, half-maximal inhibitory concentration: 42600 nM
Beside the measured number, compound 4's estimate is 1.2-fold (0.09 log units) below it, and the stated range covers the measured number.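

In this assay, compound 4 gives the series a second true number, so the ester chain can now be compared on measured values: a 1.7-fold higher number from compound 3 to compound 4 (0.24 log units; within the scatter). Nitrooxy in place of 2-(nitrooxy)ethyl, on a saturated chain carbon, three bonds along the chain from an oxygen next to a carbonyl group, therefore keeps the read-out within the scatter, and compound 4 stays clear of the limit. The steps of an at least 1.1-fold lower number from compound 2 to compound 4 (0.06 log units; that floor lies within the scatter) and an at least 1.1-fold lower number from compound 1 to compound 4 (0.06 log units; that floor lies within the scatter) are floors only and fix no size for either change: the limit of > 50000 nM in this assay, at which 2 of the 4 values shown sit.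

Open, as far as these compounds go, is whether a hydroxyl or an amine in place of nitrooxy on the ester chain of compound 3 would move the number clearly beyond the scatter. The compounds shown also do not tell whether nitrooxy contributes to the read-out at all.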